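A few compounds are considered here, and "the series" means these few. Any claim that something is new, unique, unknown or untested is made for them only; others in the source may bear on it.

Compound 3 `O=C(O)CCCNC(=O)c1cc(=O)c2ccccc2o1` gives in a functional assay on the whole organism for inhibition, with Rattus norvegicus as the target, with a stated time of 30 min, at a dose of 1 mg/kg by the intravenous route (on this read-out lower numbers stand for less inhibition and higher numbers for more inhibition at the one dose given (going by the name of the read-out)), 0%, level with compound 1 `Cn1nnnc1NC(=O)c1cc(=O)c2ccccc2o1` at 0% and with compound 2 `O=C(O)CCNC(=O)c1cc(=O)c2ccccc2o1` at 0%. Across the measured set the steps of no change at the digits printed from compound 1 to compound 2 (within the scatter), no change at the digits printed from compound 1 to compound 3 (within the scatter) and no change at the digits printed from compound 2 to compound 3 (within the scatter) all stay within the scatter, so no substituent on the amide-type nitrogen has moved the read-out. Compound 4 `O=C(Nc1nc[nH]n1)c1cc(=O)c2ccccc2o1` differs from compound 3 by 1H-1,2,4-triazol-3-yl in place of 3-carboxypropyl on an amide-type nitrogen. The step that bears most on this is no change at the digits printed from compound 1 to compound 3 (within the scatter), where 1-methyl-1H-tetrazol-5-yl on the amide-type nitrogen gave way to 3-carboxypropyl without effect in this assay. Returning to a small heteroaromatic ring at the same place is therefore expected to give no change at the digits printed from compound 3 to compound 4 (within the scatter), nothing beyond the scatter. For compound 4 in this assay the estimate is 0%, with a range from 0% to 10%.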

Compound 4, a percentage reported as inhibition, in the whole organism at one dose (the size of the read-out at that dose, not a potency): 0%
For compound 4 middle estimate and measured number coincide at the digits printed; measured number inside the range.
By their numbers in this assay, from the lowest: compounds 1, 2, 3 and 4 (each within the scatter of the next).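

The read-out shows no change at the digits printed from compound 3 to compound 4 (within the scatter) and no change at the digits printed from compound 2 to compound 4 (within the scatter) and no change at the digits printed from compound 1 to compound 4 (within the scatter) in this assay when 1H-1,2,4-triazol-3-yl sits on the amide-type nitrogen. A second five-membered aromatic ring therefore reads the same as 1-methyl-1H-tetrazol-5-yl and both carboxylic acid chains, so the flat result is not confined to a single ring type. No data at hand explain this flat read-out.

On these data alone, whether an amine or a longer chain on the amide-type nitrogen, or a change on the shared core, would lift the read-out remains open. Also open, as far as these compounds go, is whether these compounds separate at another dose.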